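Opening the pyrrolidine ring of a weak topoisomerase inhibitor

The source may report more compounds than this note shows. Statements on the series, on what has been measured and on what is new or still open speak of the compounds shown alone.

Compound 1 `CN[C@@H]1CCN(c2cc3c(cc2F)c(=O)c(C(=O)O)cn3Cc2ccc(-c3ccccc3)cc2)C1` gives 34800 nM in an assay on isolated protein for inhibition of DNA topoisomerase 1 (Homo sapiens), with a stated time of 15 min (a higher number here means a weaker inhibitor, a lower number a stronger inhibitor), the lower of the two numbers recorded so far; compound 2 `CN[C@@H]1CCN(c2c(F)cc3c(=O)c(C(=O)O)cn(Cc4ccc(-c5ccccc5)cc4)c3c2OC)C1` gives 57700 nM, and the step of a 1.7-fold higher number from compound 1 to compound 2 (0.22 log units; within the scatter) is within the scatter. Compound 3 `CNCCNc1cc2c(cc1F)c(=O)c(C(=O)O)cn2Cc1ccc(-c2ccccc2)cc1` carries (2-(methylamino)ethyl)amino in place of 3-(methylamino)pyrrolidin-1-yl on an aromatic carbon. For the measured compounds named here, no measured step touches this change, so the expectation rests on nothing beyond the two weak numbers. The step of a 1.3-fold higher number from compound 1 to compound 3 (0.11 log units; within the scatter) is expected to stay within the scatter. For compound 3 the estimate is 45000 nM, with a range from 15000 nM to 150000 nM.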

Compound 3, half-maximal inhibitory concentration: > 200000 nM
Compound 3 gave a limit, no number (the forecaster's own chance of this, stated with the estimate: 10%); middle value at least 4.4-fold (0.64 log units) from the limit.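

Putting the open (2-(methylamino)ethyl)amino chain in place of the 3-(methylamino)pyrrolidin-1-yl ring on this aromatic carbon gives an at least 5.7-fold higher number from compound 1 to compound 3 (0.75 log units; beyond the scatter), the first step among these compounds to go beyond the scatter. In this assay compound 3 reads as a limit of the assay, not a number: the limit of > 200000 nM in this assay, at which 1 of the 3 values shown sits. So the true size of this loss is unknown, and an already weak inhibitor gets weaker still. Open, as far as these compounds go, is whether a longer chain, a primary amine at the chain's end or a piperazine ring on this carbon would match compound 1. For the compounds shown here, the single step also cannot separate losing the ring from the other differences between the two groups.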